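A ring swap on compound 1

The source may report more compounds than this note shows. Statements on the series, on what has been measured and on what is new or still open speak of the compounds shown alone.

Measured in a physicochemical assay for solubility; a lower number here means a less soluble compound, a higher number a more soluble compound:
compound 1 `CN1CCN(c2cc(C(F)(F)F)ccc2[C@H]2CCOc3cc(S(=O)(=O)Nc4nccs4)ccc32)CC1`: 176000 nM
compound 2 `O=S(=O)(Nc1nccs1)c1ccc2c(c1)OCC[C@H]2c1ccc(C(F)(F)F)cc1-n1ccnn1`: 154000 nM
compound 3 `O=S(=O)(Nc1ccncn1)c1ccc2c(c1)OCC[C@@H]2c1ccc(C(F)(F)F)cc1-c1ccc(F)cn1`: 181000 nM

Compound 1, at 176000 nM, sits level with the other two measured compounds. Its gaps to both lie within the scatter of repeated measurements, so no order can be read among the three.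

Compound 4 `O=C1COCCN1c1cc(C(F)(F)F)ccc1[C@H]1CCOc2cc(S(=O)(=O)Nc3nccs3)ccc21` has not yet been measured. It differs from compound 1 in one place, with 3-oxomorpholin-4-yl in place of 4-methylpiperazin-1-yl on an aromatic carbon.

Going by the values given here, no pair of measured compounds shows directly what a change in one place does in this assay. The best available guide is indirect. Compound 2, at 154000 nM, and compound 3, at 181000 nM, carry other groups in that place, and both remain within the scatter of compound 1. Among the compounds with values here, with only three compounds, this is slender evidence, so the expected range is kept wide.

The expected step, a 1.1-fold lower number from compound 1 to compound 4 (0.03 log units; within the scatter), stays within the scatter and has no clear direction. For compound 4 the estimated value is 165000 nM, with an expected range from 80000 nM to 320000 nM.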

Compound 4, solubility: 695000 nM
Beside the measured number, compound 4's estimate is 4.2-fold (0.62 log units) below it, and the stated range ends below it.
By their numbers in this assay, from the lowest: compounds 2, 1 and 3 (each within the scatter of the next); then compound 4.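

In this assay, going by these compounds alone, putting 3-oxomorpholin-4-yl in place of 4-methylpiperazin-1-yl gives a 3.9-fold higher number from compound 1 to compound 4 (0.60 log units; beyond the scatter) and provides the first reading of a change in one place in this set. This position, on an aromatic carbon ortho to a large group and meta to a trifluoromethyl group, is therefore not indifferent to the group it carries. The shift comes even though the two groups match in heavy atoms, ring size, hydrogen-bond donors, hydrogen-bond acceptors and net charge, leaving the mix of atoms and the double bond outside aromatic rings as the counted differences.

Going by these compounds, a simple morpholin-4-yl group at the same place would help to separate the contribution of the carbonyl from that of the ring oxygen, and whether the step holds with other cores also remains open. No measurement of any property of these two groups accompanies the result, so the data give no explanation for the step.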